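Removing the Butyl Chain at a Cytotoxicity Limit

The source may hold more compounds than are shown below. What is called first, only, known or untested is meant among the compounds shown, and "the series" means these compounds.

Compound 1, `CCCCCNc1cnc(C(=O)NCc2ccccc2)cn1`, gives > 100000 nM in an ADME assay on HEL cells (Homo sapiens) for cytotoxicity, read by microscopy, with a stated time of 6 days (on this read-out higher numbers stand for lower toxicity in this test and lower numbers for higher toxicity in this test), which is a limit of the assay.
Compound 2, `CCCCCCCNc1cnc(C(=O)NCc2ccccc2)cn1`, gives > 100000 nM in this assay, again a limit.
Compound 3, `CCCCCCCCNc1nccnc1C(=O)NCc1ccccc1`, gives > 100000 nM in this assay, also a limit.

Every measured value in this study sits at the limit of > 100000 nM in this assay, at which 3 of the 3 values shown sit. Compound 3 therefore stands at the limit rather than at a number, and the two other values shown stand there as well. Among the measured compounds shown here, the only pair of measured compounds that differ in one place is joined by a step that the two limits leave unreadable from compound 1 to compound 2, and both of its ends are limits, so the size of that step cannot be read.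

Compound 4, `CCCCNc1nccnc1C(=O)NCc1ccccc1`, is not yet measured. It differs from compound 3 by hydrogen in place of butyl on a saturated chain carbon, four bonds along the chain from a nitrogen on an aromatic ring. For the measured compounds named here, no measured step covers this change, and the one step available, a step that the two limits leave unreadable from compound 1 to compound 2, is itself unreadable. Since every value shown sits at the limit of > 100000 nM in this assay, at which 3 of the 3 values shown sit, no step beyond the scatter in this assay is expected in either direction, and the outcome most likely remains a limit. Compound 4 is therefore estimated at 100000 nM, with a range from 50000 nM to 200000 nM. The expected step is a number no higher from compound 3 to compound 4 (the limit leaves the size open).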

Compound 4, minimum cytotoxic concentration: > 100000 nM
Compound 4: a limit, no number (the forecaster's own chance of this, stated with the estimate: 85%); the middle value sits exactly at the limit.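

Compound 4, like compound 3, stands at a limit, so no new step can be read between them: the limit of > 100000 nM in this assay, at which 4 of the 4 values shown sit.

In this assay the compounds shown leave open whether changing the chain on the shared core shifts the minimum cytotoxic concentration at all, and what number any of these compounds would give.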